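A few compounds are considered here, and "the series" means these few. Any claim that something is new, unique, unknown or untested is made for them only; others in the source may bear on it.

Going by the values given here, compound 2 `CCC1=C(O)c2c(oc(-c3ccccc3C)cc2=O)C(CC)(CC)C1=O` stands at 2.41 uM in a functional assay on KBVIN cells (Homo sapiens) for antiproliferative activity, read by sulforhodamine B assay, with a stated time of 3 days (a lower number here means that less compound is needed, a higher number that more compound is needed for the effect), as the higher of the two numbers so far, while compound 1 `CCC1=C(O)c2c(oc(-c3ccc(CC)cc3)cc2=O)C(CC)(CC)C1=O` stands at 0.07 uM on the same read-out. Compound 3 `CCC1=C(O)c2c(oc(-c3ccc(C)cc3C)cc2=O)C(CC)(CC)C1=O` differs from compound 2 by methyl in place of hydrogen on an aromatic carbon in the change from 2-methylphenyl to 2,4-dimethylphenyl. Among the compounds with values here, the one measured step that bears on this, a 34-fold higher number from compound 1 to compound 2 (1.54 log units; beyond the scatter) with 2-methylphenyl in place of 4-ethylphenyl, is large but changes the group as a whole. A moderate move to a lower number in this assay is therefore expected, with a 4.0-fold lower number from compound 2 to compound 3 (0.60 log units; beyond the scatter) as the estimated step. Compound 3 is expected at 0.6 uM within an estimated range of 0.15 uM to 2.5 uM on this reasoning.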

Compound 3, concentration for half-maximal effect: 8.52 uM
Estimate against measurement, compound 3: 14-fold (1.15 log units) below; the whole stated range lies below it.
By their numbers in this assay, from the lowest: compound 1; then compound 2; then compound 3.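

Methyl on the aromatic carbon para to a large group, added to the 2-methylphenyl of compound 2, gives a 3.5-fold higher number from compound 2 to compound 3 (0.55 log units; beyond the scatter) in this assay, so filling this position does not by itself lower the number. Against the 4-ethylphenyl of compound 1, the 2,4-dimethylphenyl gives a 120-fold higher number from compound 1 to compound 3 (2.09 log units; beyond the scatter) and stands as the highest of the series, so a group at this position does not suffice when the 2-methyl is also present. No measurement here explains the direction of this step.

On these data alone, whether 4-methylphenyl without the 2-methyl would sit near compound 1 remains open. So does the effect of a longer chain such as propyl or of a methoxy group at this position.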